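A few compounds are considered here, and "the series" means these few. Any claim that something is new, unique, unknown or untested is made for them only; others in the source may bear on it.

Measured compounds:
- compound 1, `O=C1C=C(Nc2ccc(Br)cc2)C(=O)c2[nH]c(-c3ccccn3)nc21`, in an ADME assay (Rattus norvegicus) for inhibition (on this read-out higher numbers stand for weaker inhibition and lower numbers for stronger inhibition), compound 1 gives 12000 nM
- compound 2, `CCOc1ccc(NC2=CC(=O)c3nc(-c4ccccn4)[nH]c3C2=O)cc1`, where compound 2 gives 6500 nM
- compound 3, `Cc1nc2c(nc1C)C(=O)C(Nc1ccc(Br)cc1)=CC2=O`, where compound 3 gives 1100 nM

Compounds 1 and 2 share a core and differ only by ethoxy in place of bromo on an aromatic carbon; that change gave a 1.8-fold lower number from compound 1 to compound 2 (0.27 log units; within the scatter). Compound 3 carries a different core; how the two cores differ is not broken down here. Its number stands lowest of the three, beyond the scatter from both compounds 1 and 2.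

Compound 4, `CCOc1ccc(NC2=CC(=O)c3nc(C)c(C)nc3C2=O)cc1`, is not yet measured. It carries the core of compound 3 and differs from compound 3 by ethoxy in place of bromo on an aromatic carbon, the same change as between compounds 1 and 2. Since that change moved compound 1 to compound 2 by a 1.8-fold lower number from compound 1 to compound 2 (0.27 log units; within the scatter), a step of about the same size is expected here, so that compound 4 is estimated at 700 nM, with a range from 300 nM to 1800 nM, meaning an expected step of a 1.6-fold lower number from compound 3 to compound 4 (0.20 log units; within the scatter).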

Compound 4, half-maximal inhibitory concentration: 1500 nM
The estimate for compound 4 lay 2.1-fold (0.33 log units) below the measured number; low and high end bracket the measured number.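

In this assay, ethoxy in place of bromo on an aromatic carbon gives a 1.4-fold higher number from compound 3 to compound 4 (0.13 log units; within the scatter) on the core of compound 3, and the two steps now available compare as follows: the same change on two cores in this assay, a 1.8-fold lower number (0.27 log units; within the scatter) from compound 1 to compound 2 and a 1.4-fold higher number (0.13 log units; within the scatter) from compound 3 to compound 4, 2.5-fold (0.40 log units) apart, within the scatter of two such steps

On these two cores, the change therefore carries over as a step within the scatter, and the opposite printed directions of the two steps cannot be told apart. Two pairs do not show that the step would stay this small on a further core, nor do they give its true size on either core.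

On these data alone, it remains open whether an amine, a carboxylic acid or a longer chain in the same place would move the number beyond the scatter. Also open, as far as these compounds go, is whether such a group would behave alike on both cores.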